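Chloro for methoxycarbonyl on a quinoline urea: permeability outlook

A few compounds are considered here, and "the series" means these few. Any claim that something is new, unique, unknown or untested is made for them only; others in the source may bear on it.

Measured compounds:
compound 1 `Cc1cc(NC(=O)Nc2ccc(C)c(Cl)c2)c2ccccc2n1` — 262 10^-6 cm/s
compound 2 `COC(=O)c1ccc(NC(=O)Nc2cc(C)nc3ccccc23)cc1` — 448 10^-6 cm/s
compound 3 `COc1ccc(NC(=O)Nc2cc(C)nc3ccccc23)cc1F` — 50 10^-6 cm/s

In an ADME assay for permeability, using PAMPA, at pH 7.4 (a lower number here means that the compound crosses the layer more slowly, a higher number that the compound crosses the layer faster), compound 2 gives the highest of the three numbers. Compound 1 comes closest, its value lying within the scatter of compound 2, while compound 3 stands far below, beyond the scatter. Compound 4 `Cc1cc(NC(=O)Nc2ccc(Cl)cc2)c2ccccc2n1` has not been measured. It differs from compound 2 in one place: chloro in place of methoxycarbonyl on an aromatic carbon. Because compound 1 gives 262 10^-6 cm/s while also bearing a chloro, a step to compound 4 of modest size is expected, downward if at all, and plausibly within the scatter. The step of a 1.6-fold lower number from compound 2 to compound 4 (0.20 log units; within the scatter) is the estimated outcome. Compound 4 is expected to give 280 10^-6 cm/s, between 120 10^-6 cm/s and 600 10^-6 cm/s.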

Compound 4, apparent permeability: 537 10^-6 cm/s
For compound 4 the middle estimate is 1.9-fold (0.28 log units) below the measured one; measured number inside the range.
By their numbers in this assay, from the lowest: compound 3; then compounds 1, 2 and 4 (each within the scatter of the next, the first and the last beyond it).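

Swapping methoxycarbonyl for chloro on this aromatic carbon, para to a large group, gives in this assay a step of a 1.2-fold higher number from compound 2 to compound 4 (0.08 log units; within the scatter). Going by these compounds alone, compound 2 and compound 4 therefore stand level, so at this position a single chlorine atom reads the same as the larger group with its hydrogen-bond acceptors, a comparison the earlier compounds did not offer. No data at hand bear on why the two match. Going by these compounds, whether an amine, a carboxylic acid or a longer chain at this place would also stay level remains open.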